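Trading a Large Ring Nitrogen Group for Methyl

The source may report more compounds than this note shows. Statements on the series, on what has been measured and on what is new or still open speak of the compounds shown alone.

In a functional assay on HCT-116 cells (Homo sapiens) for inhibition, read by CCK-8 assay, with a stated time of 48 h (on this read-out lower numbers stand for stronger inhibition and higher numbers for weaker inhibition), compound 1 (`COc1ccc(CN(C(=O)CSC(=S)N2CCN(C)CC2)c2cc(OC)c(OC)c(OC)c2)cc1`) gives 2640 nM. Compound 2 (`COc1ccc(CN(C(=O)CSC(=S)N2CCN(C(=O)OC(C)(C)C)CC2)c2cc(OC)c(OC)c(OC)c2)cc1O`) gives 128 nM, the lower of the two numbers, and the gap between them lies beyond the usual scatter. So far, no pair of measured compounds isolates a single structural change. Compound 3 (`COc1ccc(CN(C(=O)CSC(=S)N2CCN(C)CC2)c2cc(OC)c(OC)c(OC)c2)cc1O`) has not yet been measured. It has methyl in place of tert-butoxycarbonyl on an amine nitrogen in a ring, a swap counted as methyl in place of tert-butoxycarbonyl on an amine nitrogen in a ring. With so little data, any forecast is rough, but the expectation leans toward the higher number, the 2640 nM of compound 1. A moderate rise in this assay is therefore expected, and a 2.3-fold higher number from compound 2 to compound 3 (0.37 log units; beyond the scatter) is the estimated step. The estimate for compound 3 is 300 nM, with an expected range from 90 nM to 1000 nM.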

Compound 3, half-maximal inhibitory concentration: 810 nM
Compound 3: middle estimate off by 2.7-fold (0.43 log units), on the low side, and the stated range covers the measured number.
By their numbers in this assay, from the lowest: compound 2; then compound 3; then compound 1.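

In this assay, among the compounds shown here, putting methyl in place of tert-butoxycarbonyl on the amine nitrogen in the ring gives a 6.3-fold higher number from compound 2 to compound 3 (0.80 log units; beyond the scatter), the first clean evidence that the group at this nitrogen affects the read-out on its own. Hydroxy in place of hydrogen on an aromatic carbon gives a 3.3-fold lower number from compound 1 to compound 3 (0.51 log units; beyond the scatter), so the wide gap seen earlier reflects two separate changes that each shift the number, with the larger step at the ring nitrogen. Nothing measured here explains either step.

From the compounds shown here alone, only these two groups appear on the ring nitrogen, so it remains open how an acetyl or benzyl group, or a plain hydrogen, would behave there. Going by these compounds, it is also open whether the hydroxy step would have the same size with tert-butoxycarbonyl on that nitrogen.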